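Aryl exchange on the ring nitrogen: notes toward compound 4

The source may report more compounds than this note shows. Statements on the series, on what has been measured and on what is new or still open speak of the compounds shown alone.

Values in a functional assay on PC-12 cells (Rattus norvegicus) for cytotoxicity, read by MTT assay, with stated times of 2 h and 24 h, tested at 5 uM (on this read-out higher numbers stand for a stronger effect at the one concentration tested and lower numbers for a weaker effect), for the three measured members:
compound 1 `Oc1cc(C(F)(F)F)ccc1-c1nc(-c2ccccc2O)n(-c2ccc(Br)cc2)n1`: 89.8%
compound 2 `Oc1cc(C(F)(F)F)ccc1-c1nc(-c2ccccc2O)n(-c2ccc(C(F)(F)F)cc2)n1`: 90.5%
compound 3 `Oc1cc(C(F)(F)F)ccc1-c1nc(-c2ccccc2O)n(-c2cccc(Cl)c2)n1`: 92.7%

Compound 3 holds the highest of the three numbers, but a number 2.2 percentage points higher from compound 2 to compound 3 (within the scatter) and a number 2.9 percentage points higher from compound 1 to compound 3 (within the scatter) are both within the scatter, so the three compounds are not separated by these data.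

The next member is compound 4 `Oc1cc(C(F)(F)F)ccc1-c1nc(-c2ccccc2O)n(-c2cc(F)cc(F)c2)n1`. Compared with compound 3, (3,5-difluorophenyl in place of 3-chlorophenyl on an aromatic nitrogen).

Among the compounds with values here, the steps that bear on this are the two that already exchange the aryl group on the same ring nitrogen: a number 2.9 percentage points higher from compound 1 to compound 3 (within the scatter) and a number 2.2 percentage points higher from compound 2 to compound 3 (within the scatter), both within the scatter. The remaining step, a number 0.7 percentage points higher from compound 1 to compound 2 (within the scatter), changes only the substituent on that aryl group and is also within the scatter. Across the three measured compounds, nothing on this aryl group has moved this assay beyond its usual variation, so for compound 4 no step beyond the scatter is expected in either direction, a number 2.7 percentage points lower from compound 3 to compound 4 (within the scatter).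

Compound 4 is therefore estimated at 90% in this assay, with a range from 80% to 97%.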

Compound 4, a percentage reported as activity, at one concentration (the size of the read-out at that concentration, not a potency): 100%
The estimate for compound 4 lay 10 percentage points below the measured number; measured number outside the range, above it.
By their numbers in this assay, from the lowest: compounds 1, 2, 3 and 4 (each within the scatter of the next, the first and the last beyond it).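

Within the data shown here, on the aryl group carried by the ring nitrogen, a number 10.2 percentage points higher from compound 1 to compound 4 (beyond the scatter) in this assay is the first step to clear the usual variation, a modest one in which 3,5-difluorophenyl replaces 4-bromophenyl. Among these compounds, the same group does not separate from the other two aryl groups, with a number 9.5 percentage points higher from compound 2 to compound 4 (within the scatter) and a number 7.3 percentage points higher from compound 3 to compound 4 (within the scatter) both within the scatter, so compound 4 stands apart from compound 1 alone and the exchange at this position has so far moved the read-out beyond its variation in only this one pair. No measurement at hand accounts for this step.

All four aryl groups here carry only halogen or trifluoromethyl substituents, so the compounds shown leave open how an aryl group bearing an amine, a carboxylic acid or a longer alkyl chain would read in this assay. Also open, on these data alone, is whether the separation of compound 4 from compound 1 would persist at other concentrations, as a read-out at one concentration gives the size of an effect and not a potency.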